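Series notes: hydrogen in place of bromo

A few compounds are considered here, and "the series" means these few. Any claim that something is new, unique, unknown or untested is made for them only; others in the source may bear on it.

Measured so far:
compound 1 `CCCSc1nc(N/N=C/c2cccs2)c2nnn(Cc3ccccc3)c2n1`; in a functional assay on MCF7 cells (Homo sapiens) for antiproliferative activity, read by MTT assay, with a stated time of 72 h (a lower number here means a stronger inhibitor, a higher number a weaker inhibitor), compound 1 reaches only a limit, > 64000 nM.
compound 2 `CCCSc1nc(N/N=C(\C)c2ccc(Br)cc2)c2nnn(Cc3ccccc3)c2n1`; in this assay compound 2 gives 13000 nM.

Within the data shown here, compound 2 holds the only real number in this set; the other value is a limit, not a number. Among the measured compounds shown here, the step of an at least 4.9-fold lower number from compound 1 to compound 2 (0.69 log units; beyond the scatter) is the sole measured step, and its true size is open because it rests on (the limit of > 64000 nM in this assay, at which 1 of the 2 values shown sits). Compound 3 `CCCSc1nc(N/N=C(\C)c2ccccc2)c2nnn(Cc3ccccc3)c2n1` differs from compound 2 by hydrogen in place of bromo on an aromatic carbon. For the measured compounds named here, no measured step removes a bromo on its own: the step of an at least 4.9-fold lower number from compound 1 to compound 2 (0.69 log units; beyond the scatter) swaps an entire group on a nitrogen on an aromatic ring, so it bears only loosely on this change and sets no direction for it. A small move toward a higher number is expected, within or close to the scatter. Compound 3 is estimated at 22000 nM, with a range from 7000 nM to 64000 nM. The expected step is a 1.7-fold higher number from compound 2 to compound 3 (0.23 log units; within the scatter), and a report of only a limit remains possible.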

Compound 3, half-maximal inhibitory concentration: 32100 nM
The estimate for compound 3 lay 1.5-fold (0.16 log units) below the measured number; the measured number falls inside the stated range.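

In this assay, among these compounds, the 4-bromophenyl to phenyl change gives a 2.5-fold higher number from compound 2 to compound 3 (0.39 log units; beyond the scatter), the first measured step that isolates the bromo on this aromatic carbon, para to a large group; at this place, bromo gives a lower number than hydrogen, by a modest margin. With no bromo on the six-membered ring, the swap for the five-membered aromatic ring with 1 hetero atom gives an at least 1.9-fold lower number from compound 1 to compound 3 (0.29 log units; that floor lies within the scatter), so this pair no longer shows a lowering clearly beyond the scatter. Compound 1 reaches only a limit, and the true size of that step stays open: the limit of > 64000 nM in this assay, at which 1 of the 3 values shown sits.

Going by these compounds, only bromo and hydrogen are compared at this carbon, so it remains open whether a chloro, a methoxy or an amine there would give a number nearer to that of compound 2 or compound 3. On these data alone, it is also open whether the bromo step would keep its direction and size with a longer chain on the sulfur of the shared core.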